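Arylpiperazine acetamides as fatty acid transport protein 1 inhibitors

The source may report more compounds than this note shows. Statements on the series, on what has been measured and on what is new or still open speak of the compounds shown alone.

Measured compounds:
compound 1 `O=C(CN1CCN(c2ccc(F)cn2)CC1)Nc1nc2c(o1)CCCC2` — 1700 nM
compound 2 `O=C(CN1CCN(c2ccncc2)CC1)Nc1nc2c(s1)CCCC2` — > 10000 nM
compound 3 `O=C(CN1CCN(c2ccc(F)cc2)CC1)Nc1nc2c(s1)CCCCC2` — 2000 nM

In an assay on isolated protein for inhibition of long-chain fatty acid transport protein 1 (Mus musculus), read by scintillation counting, with a stated time of 20 min (on this read-out lower numbers stand for stronger inhibition and higher numbers for weaker inhibition), compound 1 gives 1700 nM and compound 3 gives 2000 nM; these two values lie within the scatter of each other. For compound 2 this assay gives only a limit, > 10000 nM, so no number is known for it (the limit of > 10000 nM in this assay, at which 1 of the 3 values shown sits). Compound 2 therefore stands apart from compounds 1 and 3 in that its inhibition was too weak to be quantified under the conditions of this assay.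

Compound 4 `Cc1ccc(N2CCN(CC(=O)Nc3nc4c(s3)CCCC4)CC2)cc1` has not yet been measured. It differs from compound 2 in one place: 4-methylphenyl in place of pyridin-4-yl on an amine nitrogen in a ring. Both compounds 1 and 3, which carry a six-membered carbon-only aromatic ring on the ring amine nitrogen, return measurable numbers in this assay, whereas compound 2 with its pyridin-4-yl does not.

On that basis the step from compound 2 to compound 4 is expected to run toward stronger inhibition, beyond the scatter, with an expected size of an at least 3.3-fold lower number from compound 2 to compound 4 (0.52 log units; beyond the scatter). Compound 4 is accordingly estimated at 3000 nM, with a range from 1000 nM to 10000 nM; a result reported only as a limit remains possible.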

Compound 4, half-maximal inhibitory concentration: > 10000 nM
Compound 4 gave a limit, no number; the forecaster's own chance of this, stated with the estimate: 25%; at least 3.3-fold (0.52 log units) between middle value and limit.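

Compound 4 gives > 10000 nM, which is a limit and not a number, so the step from compound 2, also held only by a limit, cannot be read: the limit of > 10000 nM in this assay, at which 2 of the 4 values shown sit.

The compounds shown leave open whether 4-methylphenyl in place of pyridin-4-yl changes inhibition at all, and what number either compound would give.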